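The compounds below may be only part of what the source reports. "The series", "measured", "known", "first", "only" and "open" are said of these compounds alone.

Compound 1 `COc1cc(-c2nnc3n2NC(c2ccco2)C(C(=O)c2cccc(Br)c2)S3)cc(OC)c1OC` gives 91800 nM in a functional assay on MCF7 cells (Homo sapiens) for cytotoxicity, read by MTT assay, with a stated time of 48 h; a lower number here means a stronger inhibitor, a higher number a weaker inhibitor. Compound 2 `COc1cc(-c2nnc3n2NC(c2ccco2)C(C(=O)c2ccc(-c4ccccc4)cc2)S3)cc(OC)c1OC` reaches only the limit of > 100000 nM in this assay. Compound 3 `COc1cc(-c2nnc3n2NC(c2ccco2)C(C(=O)c2ccccc2C)S3)cc(OC)c1OC` gives 69900 nM in this assay.

Among the two plain numbers, compound 3 and compound 1 are not separated: a 1.3-fold lower number from compound 1 to compound 3 (0.12 log units; within the scatter). Compound 4 `COc1cc(-c2nnc3n2NC(c2ccco2)C(C(=O)c2ccc(O)cc2)S3)cc(OC)c1OC` differs from compound 3 in one place, (4-hydroxyphenyl in place of 2-methylphenyl on a carbonyl carbon). The three measured steps all swap the aromatic group on the same carbonyl carbon, and none moves beyond the scatter: an at least 1.0-fold higher number from compound 1 to compound 2 (0.03 log units; that floor lies within the scatter), an at least 1.4-fold lower number from compound 2 to compound 3 (0.15 log units; that floor lies within the scatter), a 1.3-fold lower number from compound 1 to compound 3 (0.12 log units; within the scatter). No step beyond the scatter is therefore expected in this assay for compound 4, in either direction. Compound 4 is estimated at 80000 nM, with a range from 35000 nM to 200000 nM. The expected step is a 1.1-fold higher number from compound 3 to compound 4 (0.06 log units; within the scatter).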

Compound 4, half-maximal inhibitory concentration: 88900 nM
Estimate against measurement, compound 4: 1.1-fold (0.05 log units) below, within the range that was stated.
By their numbers in this assay, from the lowest: compounds 3, 4 and 1 (each within the scatter of the next). At a limit, above all of these: compound 2.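

Replacing 2-methylphenyl with 4-hydroxyphenyl on the carbonyl carbon adds a hydrogen-bond donor and acceptor, yet in this assay this gives no separation: a 1.3-fold higher number from compound 3 to compound 4 (0.10 log units; within the scatter). The comparison with the 3-bromophenyl group is equally flat: a 1.0-fold lower number from compound 1 to compound 4 (0.01 log units; within the scatter). The third step gives only a floor, an at least 1.1-fold lower number from compound 2 to compound 4 (0.05 log units; that floor lies within the scatter), since one of its two values is a limit: the limit of > 100000 nM in this assay, at which 1 of the 4 values shown sits.

From the compounds shown here alone, whether any group on this carbonyl carbon can move the number beyond the scatter remains open. An aromatic amine or a carboxylic acid there would test this, as neither is among the compounds shown.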